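This account rests on a few compounds, and the source may have more. Where it says the series, first, only, none or still open, it means among the compounds named here.

Measured in a physicochemical assay for lipophilicity, read by HPLC, measured as chromatographic lipophilicity, at pH 7.4; on this read-out higher numbers stand for higher lipophilicity and lower numbers for lower lipophilicity:
Compound 1 `CC(C)(C)C(=O)N1N=CCC1c1cc[nH]n1`: 2.7
Compound 2 `O=C(c1cccnc1)N1N=CCC1c1ccccc1`: 2.7
Compound 3 `CC(C)(C)C(=O)N1CCC1c1ccccc1`: 5

Compound 1 stands level with compound 2, the pair together lowest of the three, while compound 3 lies well above both, beyond the usual scatter. The still unmeasured compound 4 `CC(C)(C)C(=O)N1N=CCC1C1CCCC1` carries cyclopentyl in place of 1H-pyrazol-3-yl on a saturated ring carbon. Among the compounds with values here, no measured pair differs by this swap alone, so the size of the step is a judgement. A clear rise in this assay is expected, well beyond the scatter, with compound 3 at 5 as a rough guide to the upper region. The expected change is a number 1.80 log units higher from compound 1 to compound 4 (beyond the scatter). For compound 4 the estimated value is 4.5, with an expected range of 3.9 to 5.1.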

Compound 4, distribution coefficient: 6.7
Compound 4: the middle estimate sits 2.20 log units below what was measured; the whole stated range lies below it.
By their numbers in this assay, from the lowest: compounds 1 and 2 (each within the scatter of the next); then compound 3; then compound 4.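

Within the data shown here, on this saturated ring carbon, cyclopentyl in place of 1H-pyrazol-3-yl gives a large step in this assay, a number 4.00 log units higher from compound 1 to compound 4 (beyond the scatter), the first direct reading of this swap. Both groups hold 5 heavy atoms, so the swap adds no atoms: carbon replaces both nitrogens, and the hydrogen-bond donor and acceptor are gone. Nothing available explains the size of this step.

Which of these differences carries the step remains open. So does where a carboxylic acid or an amine on this carbon would fall relative to compound 1 and compound 4.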